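The source may hold more compounds than are shown below. What is called first, only, known or untested is meant among the compounds shown, and "the series" means these compounds.

Compound 1 `Nc1cc(N)c2nc(-c3ccccc3)c(NCc3ccc(Cl)c(Cl)c3)nc2c1`, compound 2 `CCOC(=O)[C@H](CCC(=O)O)NC(=O)c1ccc(Sc2nc3cc(N)cc(N)c3nc2-c2ccccc2)cc1`, compound 3 `COc1ccc(Sc2nc3cc(N)cc(N)c3nc2-c2ccccc2)cc1` and the still unmeasured compound 4 `Nc1cc(N)c2nc(-c3ccccc3)c(Sc3ccc(F)cc3)nc2c1` share one core. In a functional assay on NCI/ADR-RES cells (Homo sapiens) for inhibition, read by sulforhodamine B assay, with a stated time of 48 h (on this read-out higher numbers stand for weaker inhibition of growth and lower numbers for stronger inhibition of growth), compound 1 gives 17400 nM, while compound 2 gives 21400 nM. For compound 3 the reading is not a number but a limit of the measurement, < 100000 nM, which is the limit of < 100000 nM in this assay, at which 1 of the 3 values shown sits. Where compound 3 stands against the other two therefore cannot be fixed. Compound 4 differs from compound 3 in a single place: fluoro in place of methoxy on an aromatic carbon. Among the compounds with values here, no measured pair shows this change, so neither size nor direction of the step is known; anything from no change beyond the scatter to a clear gain remains open. Compound 4 is expected to give roughly 25000 nM in this assay, somewhere from 5000 nM to 100000 nM. That estimate amounts to a step that the limit leaves unreadable from compound 3 to compound 4, read against a limit.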

Compound 4, concentration for 50% growth inhibition: 16600 nM
Beside the measured number, compound 4's estimate is 1.5-fold (0.18 log units) above it; measured number inside the range.
By their numbers in this assay, from the lowest: compounds 4, 1 and 2 (each within the scatter of the next).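

No step can be read from compound 3 to compound 4, because compound 3 has only a limit, not a number: the limit of < 100000 nM in this assay, at which 1 of the 4 values shown sits.

On these data alone, whether fluoro in place of methoxy changes growth inhibition at all, and in which direction, stays open.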